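The compounds below may be only part of what the source reports. "The series", "measured", "known", "first", "only" and "open" are said of these compounds alone.

Measured in an assay on isolated protein for binding affinity to Leucine-rich repeat serine/threonine-protein kinase 2 (Homo sapiens), read by TR-FRET and LanthaScreen, with a stated time of 2 h; on this read-out lower numbers stand for stronger inhibition and higher numbers for weaker inhibition:

- compound 1 `Cn1c(N2CCCC2)c(C#N)c2c(N)ncnc21`: 41 nM
- compound 2 `C[C@@H]1CCCN1c1cc2c(N)ncnc2n1C`: 164 nM
- compound 3 `Cc1nn(C)cc1Nc1nc(N)c2c(C#N)c(N3CCC[C@H]3C)n(C)c2n1`: 1 nM

Compound 1 holds the second highest of the three numbers. Going by the values given here, compound 2 sits above it, beyond the usual scatter, while compound 3 sits far below it, also beyond the scatter; no single-point steps connect these three, so their gaps are read only as the values show them.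

Compound 4 `Cn1c(-n2cccc2)c(C#N)c2c(N)ncnc21` is not yet measured. Against compound 1 it carries 1H-pyrrol-1-yl in place of pyrrolidin-1-yl on an aromatic carbon. The shared core and the cyano and methyl groups stay in place; only the ring on that carbon goes from non-aromatic to aromatic. Among the compounds with values here, no measured pair shows this change, so the size of the step is uncertain. The expectation is a modest move toward weaker binding, a 2.9-fold higher number from compound 1 to compound 4 (0.47 log units; beyond the scatter), not far beyond the scatter. Compound 4 is therefore estimated at 120 nM, in a range from 30 nM to 500 nM.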

Compound 4, inhibition constant: 239 nM
Beside the measured number, compound 4's estimate is 2.0-fold (0.30 log units) below it; the range from low to high includes it.
By their numbers in this assay, from the lowest: compound 3; then compound 1; then compounds 2 and 4 (each within the scatter of the next).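

In this assay, going by these compounds alone, the change from pyrrolidin-1-yl to 1H-pyrrol-1-yl on this aromatic carbon gives a 5.8-fold higher number from compound 1 to compound 4 (0.77 log units; beyond the scatter) and is the only single-place step so far. The two groups match in heavy atoms, ring size, hetero atom, hydrogen-bond counts and charge, so this position distinguishes a non-aromatic ring from an aromatic one, with a modest step beyond the scatter. No measurement at hand accounts for the size of this step.

Still open, as far as these compounds go, is how this carbon would respond to a six-membered piperidin-1-yl ring or to an open-chain dimethylamino group. Also open, from the compounds shown here alone, is whether the same ring change would give a step of similar size on compound 3, which carries further groups on the shared core.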